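The compounds below may be only part of what the source reports. "The series", "measured", "known", "first", "only" and "open" are said of these compounds alone.

Measured compounds in the series:
compound 1 `COc1ccc(-c2cc(/C=C/C(=O)c3ccc(N)cc3)[nH]n2)cc1` gives 2560 nM
compound 2 `COc1ccc(-c2cc(/C=C/C(=O)c3ccc(N)cc3)[nH]n2)cc1OC` gives 13100 nM
compound 3 `COc1cc(C(=O)/C=C/c2cc(-c3cc(OC)c(OC)c(OC)c3)n[nH]2)cc(OC)c1OC` gives 2480 nM

All three numbers come from a functional assay on UO-31 cells (Homo sapiens) for inhibition, read by sulforhodamine B assay, with a stated time of 48 h; a lower number here means a stronger inhibitor of growth, a higher number a weaker inhibitor of growth. Compound 3 and compound 1 lie within the scatter of each other, so no order between them is claimed; compound 2 sits apart from both, beyond the scatter.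

Compound 2 and compound 1 differ in one place: hydrogen in place of methoxy on an aromatic carbon. This step gives a 5.1-fold lower number from compound 2 to compound 1 (0.71 log units; beyond the scatter). The same kind of change separates compound 3 from the unmeasured compound 4 `COc1ccc(-c2cc(/C=C/C(=O)c3cc(OC)c(OC)c(OC)c3)[nH]n2)cc1OC`: hydrogen in place of methoxy on an aromatic carbon. The surroundings are not identical word for word: in compound 3 the position is also meta to a methoxy group, which is not part of the description for compound 2, so the two changes are of the same kind but not the same. How the core of compound 3 differs from that of compound 2 is not broken down here; their values in this assay are simply what they are.

Among the measured compounds shown here, on this basis a step in the same direction is expected for compound 4, though somewhat smaller than the earlier one because only one example, a 5.1-fold lower number from compound 2 to compound 1 (0.71 log units; beyond the scatter), supports it and the setting differs: an estimated 3.1-fold lower number from compound 3 to compound 4 (0.49 log units; beyond the scatter). Compound 4 is therefore expected to give about 800 nM in this assay, plausibly between 300 nM and 2500 nM.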

Compound 4, concentration for total growth inhibition: 2590 nM
The estimate for compound 4 lay 3.2-fold (0.51 log units) below the measured number, outside the stated range (above it).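

In this assay, hydrogen in place of methoxy on an aromatic carbon, here ortho to a methoxy group and also meta to a methoxy group, gives a 1.0-fold higher number from compound 3 to compound 4 (0.02 log units; within the scatter), so no effect of the change is resolved on this core. The step seen on the core of compound 1 therefore does not carry over as a fixed increment to the core of compound 3: the same change on two cores in this assay, a 5.1-fold lower number (0.71 log units; beyond the scatter) from compound 2 to compound 1 and a 1.0-fold higher number (0.02 log units; within the scatter) from compound 3 to compound 4, 5.3-fold (0.73 log units) apart, beyond the scatter of two such steps This shows that, in this series, the size of the step on one core is not a safe guide to its size on the other, but two cores do not show which feature of either core is responsible, nor what a third core would give.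

The compounds shown leave open whether groups other than methoxy and hydrogen, such as a hydroxyl group, a fluorine atom or an ethoxy chain, would separate from hydrogen on either core in this assay. Also open, on these data alone, is how the same change from methoxy to hydrogen would read on a core carrying a nitrile or a carboxylic acid where compound 1 carries its amine.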